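Carboxypyridyl isomers on a cyclopentene acid scaffold

The source may hold more compounds than are shown below. What is called first, only, known or untested is meant among the compounds shown, and "the series" means these compounds.

Compound 1 `O=C(O)c1cncc(C2=C(c3cc(C(F)(F)F)ccc3OCc3ccccc3)CCC2)c1` and compound 2 `CSc1ccc(OCc2ccc(F)cc2)c(C2=C(c3cccc(C(=O)O)c3)CCC2)c1` share a cyclopentene core carrying an aryl acid on one double-bonded ring carbon. In an assay on isolated protein for inhibition of prostaglandin E2 receptor EP1 subtype (Homo sapiens) (a higher number here means a weaker inhibitor, a lower number a stronger inhibitor), compound 1 gives 10 nM and compound 2 gives 31.6 nM; compound 1 holds the lower of the two numbers, and its gap to compound 2 lies beyond the scatter. Compound 3 `O=C(O)c1cc(C2=C(c3cc(C(F)(F)F)ccc3OCc3ccccc3)CCC2)ccn1` keeps every atom of compound 1 but rearranges the acid-bearing ring: 2-carboxypyridin-4-yl in place of 5-carboxypyridin-3-yl on a double-bonded ring carbon. Among the compounds with values here, no measured pair shows this kind of swap, so the step from compound 1 to compound 3 in this assay can only be guessed. A modest move toward a higher number, somewhat beyond the scatter, is expected, on the order of a 3.0-fold higher number from compound 1 to compound 3 (0.48 log units; beyond the scatter). Compound 3 is therefore estimated at 30 nM in this assay, with a plausible range from 8 nM to 120 nM.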

Compound 3, half-maximal inhibitory concentration in the prostaglandin E2 receptor EP1 subtype assay: 39.8 nM
Compound 3: the middle estimate sits 1.3-fold (0.12 log units) below what was measured, and the stated range covers the measured number.
By their numbers in the prostaglandin E2 receptor EP1 subtype assay, from the lowest: compound 1; then compounds 2 and 3 (each within the scatter of the next).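

In the prostaglandin E2 receptor EP1 subtype assay, exchanging 5-carboxypyridin-3-yl for 2-carboxypyridin-4-yl on a double-bonded ring carbon gives a 4.0-fold higher number from compound 1 to compound 3 (0.60 log units; beyond the scatter). The two groups have the same atoms and the same counts, so at this position the arrangement of the acid-bearing ring alone moves the number beyond the scatter. No measurement here accounts for the shift. In a physicochemical assay for lipophilicity (on this read-out lower numbers stand for lower lipophilicity and higher numbers for higher lipophilicity), compound 1 gives 2.7, while compound 3 stands as "not determined" (no result reported), and the step there cannot be read.

Open is whether the acid itself is needed at this position, since every compound shown carries a carboxylic acid and none a tetrazole or a primary amide in its place. Also open, as far as these compounds go, is whether the step would hold with the benzyloxy and trifluoromethyl groups of compound 1 exchanged for others.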